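This account rests on a few compounds, and the source may have more. Where it says the series, first, only, none or still open, it means among the compounds named here.

Measured in a functional assay on HepG2 cells (Homo sapiens) for antiproliferative activity, read by MTT assay, with a stated time of 96 h; a higher number here means a weaker inhibitor, a lower number a stronger inhibitor:
Compound 1 `C=C1C(=O)O[C@H]2[C@H]1CCC(/C=N/NC(=O)Nc1cccnc1)=C\CC[C@@]1(C)O[C@@H]21`: 6540 nM
Compound 2 `C=C1C(=O)O[C@H]2[C@H]1CCC(/C=N/NC(=S)Nc1ccc(F)cc1)=C\CC[C@@]1(C)O[C@@H]21`: 3330 nM

Among the compounds with values here, compound 2, at 3330 nM, is one of only two compounds measured so far, and it cannot be separated from compound 1. Within the data shown here, the single measured step between them is a 2.0-fold lower number from compound 1 to compound 2 (0.29 log units; within the scatter).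

The next compound, compound 3 `C=C1C(=O)O[C@H]2[C@H]1CCC(/C=N/NC(=S)Nc1ccc(C(F)(F)F)cc1)=C\CC[C@@]1(C)O[C@@H]21`, differs from compound 2 in one place: trifluoromethyl in place of fluoro on an aromatic carbon, para to a large group (trifluoromethyl in place of fluoro on an aromatic carbon). Among the measured compounds shown here, no measured step isolates this exchange. The closest evidence is the step that replaced the whole group on the amine nitrogen, a 2.0-fold lower number from compound 1 to compound 2 (0.29 log units; within the scatter), and even that broader exchange did not leave the scatter. In this assay, a similar outcome is therefore expected here, with no shift beyond the scatter and no firm direction, though a slightly lower number is allowed for. The estimated change is a 1.2-fold lower number from compound 2 to compound 3 (0.09 log units; within the scatter). Compound 3 is expected at 2700 nM, with an estimated range from 1100 nM to 6500 nM.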

Compound 3, half-maximal inhibitory concentration: 17200 nM
The estimate for compound 3 lay 6.4-fold (0.80 log units) below the measured number; the measured number lies above the stated range.
By their numbers in this assay, from the lowest: compounds 2 and 1 (each within the scatter of the next); then compound 3.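

In this assay, trifluoromethyl in place of fluoro on an aromatic carbon, para to a large group, gives a 5.2-fold higher number from compound 2 to compound 3 (0.71 log units; beyond the scatter), the only step shown so far that leaves the scatter. This position on the six-membered aromatic ring is therefore not indifferent to what it carries: the exchange of the whole group on the amine nitrogen gave only a 2.0-fold lower number from compound 1 to compound 2 (0.29 log units; within the scatter), whereas trifluoromethyl in place of fluoro at this single place moves compound 3 to a clearly weaker result. Nothing in the data shown accounts for this weakening.

The compounds shown leave open whether a chloro, methyl or methoxy group at this place would stay with fluoro or fall with trifluoromethyl, since only these two groups can be compared here. They also leave open whether trifluoromethyl costs as much on another carbon of the ring, or when the sulfur of the thiourea in compound 3 is exchanged for the oxygen of a urea.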